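The source may report more compounds than this note shows. Statements on the series, on what has been measured and on what is new or still open speak of the compounds shown alone.

Compound 1, `CN(C)c1ccc(C(=O)N2CCC(n3cncc3-c3ccc(OS(=O)(=O)c4cccc(C(=O)NC5CC5)c4)cc3)CC2)cc1`: 1.03 nM in an assay on THP-1 cells for antagonist activity at P2X purinoceptor 7 (Homo sapiens), read by ELISA, with a stated time of 30 min; a higher number here means a weaker inhibitor, a lower number a stronger inhibitor.
Compound 2, `CS(=O)(=O)c1ccc(C(=O)N2CCC(c3nc4cc(OS(=O)(=O)c5cccc6cnccc56)ccc4[nH]3)CC2)cc1`: 43 nM in this assay.

Of the two compounds measured in this assay, compound 2 has the higher number; compound 1 gives a far lower one, and the two differ in more than one place, so the gap cannot be assigned to any single change. Compound 3, `CN(C)c1ccc(C(=O)N2CCC(c3nc4cc(OS(=O)(=O)c5cccc6cnccc56)ccc4[nH]3)CC2)cc1`, differs from compound 2 by dimethylamino in place of methylsulfonyl on an aromatic carbon. Among the measured compounds shown here, no measured pair shows this same change on this core, so the step is uncertain; a modest move toward a lower number is expected, a 1.7-fold lower number from compound 2 to compound 3 (0.24 log units; within the scatter). Compound 3 is therefore estimated at 25 nM, with a range from 8 nM to 80 nM.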

Compound 3, half-maximal inhibitory concentration: 121 nM
Compound 3: the middle estimate sits 4.8-fold (0.68 log units) below what was measured; the whole stated range lies below it.
By their numbers in this assay, from the lowest: compound 1; then compound 2; then compound 3.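

Replacing methylsulfonyl with dimethylamino on this aromatic carbon, para to a large group, gives a 2.8-fold higher number from compound 2 to compound 3 (0.45 log units; beyond the scatter) in this assay. The position therefore responds to the group it carries, and on this core methylsulfonyl gives the lower number of the two. No measurement shown here explains the step.

Going by these compounds, whether a nitrile or a carboxylic acid at this position would give a lower number remains open. So does whether the same swap would shift the number in the same direction on the core of compound 1.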